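Sulfamoyl to chloro: expected shift in rat whole-animal inhibition

A few compounds are considered here, and "the series" means these few. Any claim that something is new, unique, unknown or untested is made for them only; others in the source may bear on it.

Compound 1, `CCOC(=O)c1c(Nc2ccc(OC)cc2)ncnc1NC(C)C`, gives 62.7% in a functional assay on the whole organism with Rattus norvegicus as the target, at a dose of 50 mg/kg by the oral route; on this read-out lower numbers stand for less inhibition and higher numbers for more inhibition at the one dose given (going by the name of the read-out).
Compound 2, `CCOC(=O)c1c(NC(C)C)ncnc1Oc1ccccc1`, gives 55.5%.
Compound 3, `CCOC(=O)c1c(Nc2ccc(S(N)(=O)=O)cc2)ncnc1NC(C)C`, gives 87.7%.

Compound 3 stands highest of the three numbers in this assay. The nearest is compound 1, which lies lower by a gap beyond the scatter; the furthest is compound 2, also lower by a gap beyond the scatter.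

Compound 4, `CCOC(=O)c1c(Nc2ccc(Cl)cc2)ncnc1NC(C)C`, differs from compound 3 in one place: chloro in place of sulfamoyl on an aromatic carbon. A single measured step bears on this change, a number 25 percentage points higher from compound 1 to compound 3 (beyond the scatter), in which sulfamoyl replaced methoxy at the same spot and the number rose modestly. For the measured compounds named here, no measured step puts chloro at that spot, so the step from compound 3 to compound 4 cannot be read directly. Because a number 25 percentage points higher from compound 1 to compound 3 (beyond the scatter) was a rise on arrival of sulfamoyl, its departure is expected to lower the number again, toward the level of compound 1, with wide uncertainty. Compound 4 is therefore estimated at 66%, with a range from 45% to 87%. This corresponds to an expected step of a number 21.7 percentage points lower from compound 3 to compound 4 (beyond the scatter) in this assay, downward and beyond the scatter.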

Compound 4, a percentage reported as inhibition, in the whole organism at one dose (the size of the read-out at that dose, not a potency): 30.9%
Estimate against measurement, compound 4: 35.1 percentage points above; measured number below the stated range.
By their numbers in this assay, from the lowest: compound 4; then compounds 2 and 1 (each within the scatter of the next); then compound 3.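

In this assay, the substituent on the aromatic carbon para to a large group matters in both directions, which the earlier compounds could not show, as they had only shown a rise from methoxy to sulfamoyl. Chloro in place of sulfamoyl gives a number 56.8 percentage points lower from compound 3 to compound 4 (beyond the scatter), and it does not simply return the number to the methoxy level, since chloro in place of methoxy gives a number 31.8 percentage points lower from compound 1 to compound 4 (beyond the scatter). Across these three groups at this one spot, sulfamoyl therefore stands highest, methoxy in the middle and chloro lowest, with each step beyond the scatter.

Nothing measured here explains why these groups rank in this order. The compounds shown leave open how an amine, a carboxylic acid or a methylsulfonyl group at this position would compare with sulfamoyl, and whether the ranking would hold at other doses.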